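A few compounds are considered here, and "the series" means these few. Any claim that something is new, unique, unknown or untested is made for them only; others in the source may bear on it.

Working notes on the series. Going by the values given here, compound 2 `O=C(O)CCc1ccc(NCc2ccccc2)cc1` gives 7940 nM in a functional assay for agonist activity at Free fatty acid receptor 1 (Homo sapiens) (a higher number here means that more compound is needed for the effect, a lower number that less compound is needed), the higher of the two numbers measured so far; the nearest is compound 1 `O=C(O)CCc1ccc(NCc2ccc(Cl)s2)cc1`, which gives 2000 nM. Among the compounds with values here, the one measured step, a 4.0-fold higher number from compound 1 to compound 2 (0.60 log units; beyond the scatter), concerns a different exchange. Compound 3 `O=C(O)CCc1ccc(NCc2cccnc2)cc1` is not yet measured; it differs from compound 2 by pyridin-3-yl in place of phenyl on a saturated chain carbon bound to a nitrogen on an aromatic ring. Within the data shown here, no measured step shows this exchange, so the expectation rests on compound 2 alone, and a step near or only slightly beyond the scatter is expected, direction uncertain, a 1.3-fold higher number from compound 2 to compound 3 (0.10 log units; within the scatter). Compound 3 is therefore estimated at 10000 nM, within 4000 nM to 25000 nM.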

Compound 3, half-maximal effective concentration: < 31700 nM
Compound 3 gave a limit, no number; the forecaster's own chance of this, stated with the estimate: 15%; the middle value is on the limit's open side.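

Compound 3 gave a limit and not a number, so its steps from compound 1 and compound 2 cannot be read: the limit of < 31700 nM in this assay, at which 1 of the 3 values shown sits. The compounds shown leave open whether pyridin-3-yl in place of phenyl changes the number at all, and in which direction.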